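The compounds below may be only part of what the source reports. "The series", "measured", "known", "first", "only" and "open" are said of these compounds alone.

Compound 1 `Cc1ccc(C(=O)Nc2nc(Cl)c3cn(CC(C)(C)C)nc3n2)cc1` carries a neopentyl group on an aromatic nitrogen of the shared core. Within the data shown here, in an assay on CHO cells for displacement of a labelled ligand from adenosine receptor A3 (Homo sapiens), read by scintillation counting, with a stated time of 3 h (a lower number here means a stronger inhibitor, a higher number a weaker inhibitor), compound 1 gives 5000 nM, and the only other number recorded lies within the scatter of it. Among the measured compounds shown here, that companion, compound 2 `CC(C)(C)Cn1cc2c(Cl)nc(NC(=O)c3ccc(C(F)(F)F)cc3)nc2n1`, gives 6600 nM in this assay; the single measured step, a 1.3-fold higher number from compound 1 to compound 2 (0.12 log units; within the scatter), concerns trifluoromethyl in place of methyl on an aromatic carbon. The unmeasured compound 3 `Cc1ccc(C(=O)Nc2nc(Cl)c3cn(C(C)C)nc3n2)cc1` differs from compound 1 at another place: isopropyl in place of neopentyl on an aromatic nitrogen. For the measured compounds named here, no measured step touches the substituent on the aromatic nitrogen, so the data give no size or direction for this change; the recorded step on the aromatic carbon was itself within the scatter. The expected step, a 1.2-fold higher number from compound 1 to compound 3 (0.08 log units; within the scatter), is therefore no step beyond the scatter, held with wide uncertainty. Compound 3 is estimated at 6000 nM, with a range from 1500 nM to 25000 nM.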

Compound 3, inhibition constant: > 100000 nM
Compound 3 ended at the assay's limit (the forecaster's own chance of this, stated with the estimate: 20%); middle value at least 16-fold (1.22 log units) away from the limit.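

Isopropyl in place of neopentyl on an aromatic nitrogen gives an at least 20-fold higher number from compound 1 to compound 3 (1.30 log units; beyond the scatter) in this assay, so this position responds beyond the scatter, whereas the change on the aromatic carbon stayed within it, at a 1.3-fold higher number from compound 1 to compound 2 (0.12 log units; within the scatter). The value of compound 3, > 100000 nM, is a limit of the assay and not a number: the limit of > 100000 nM in this assay, at which 1 of the 3 values shown sits.

Both compounds shown with neopentyl, compound 1 and compound 2, give readable values, while compound 3, the only one shown with isopropyl, does not.

From the compounds shown here alone, whether a longer chain, a cyclohexyl ring or a benzyl group on this nitrogen would give a lower number than neopentyl remains open. Also open, going by these compounds, is whether trifluoromethyl in place of methyl would change anything when isopropyl sits on the nitrogen.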